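Methylseleno Analog of an Isoxazole Acylselenourea at the Assay Limit

This account rests on a few compounds, and the source may have more. Where it says the series, first, only, none or still open, it means among the compounds named here.

Compound 1, `CS/C(=N\C(=O)c1ccno1)NC(=O)c1ccno1`, was tested in a functional assay on PC-3 cells (Homo sapiens) for cytotoxicity, read by MTT assay, with a stated time of 72 h; on this read-out higher numbers stand for weaker inhibition of growth and lower numbers for stronger inhibition of growth. In this assay compound 1 gives only a limit of the assay, > 100000 nM. Compound 2, `O=C(/N=C(/NC(=O)c1ccno1)[Se]Cc1ccccc1)c1ccno1`, in this assay likewise gives only a limit, > 100000 nM. Within the data shown here, the one measured step reads a step that the two limits leave unreadable from compound 1 to compound 2, so its size cannot be read. Compound 2 therefore stands at the limit itself, as summed up in the limit of > 100000 nM in this assay, at which 2 of the 2 values shown sit.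

Compound 3, `C[Se]/C(=N\C(=O)c1ccno1)NC(=O)c1ccno1`, differs from compound 2 by hydrogen in place of phenyl on a saturated chain carbon bound to a selenium atom. The measured step bears on the same place, yet gives no readable size. The closest analog of compound 3 is compound 1, which sits at the limit > 100000 nM. Compound 3 is thus expected to stay at the limit, with a step of a number no higher from compound 2 to compound 3 (the limit leaves the size open) expected to be none beyond the scatter. The estimate for compound 3 in this assay is 100000 nM, ranging from 30000 nM to 300000 nM.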

Compound 3, concentration for total growth inhibition: 39300 nM
Compound 3: middle estimate off by 2.5-fold (0.41 log units), on the high side; the measured number falls inside the stated range.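

In this assay, this position now gives a readable change where the earlier pair gave none: hydrogen in place of phenyl on a saturated chain carbon bound to a selenium atom, that is, benzyl to methyl, gives an at least 2.5-fold lower number from compound 2 to compound 3 (0.40 log units; beyond the scatter). With the methyl group kept, selenium in place of sulfur gives an at least 2.5-fold lower number from compound 1 to compound 3 (0.40 log units; beyond the scatter), so the change of this one atom also registers in the read-out. Among these compounds, compound 3 is the only one of the three compounds with a value short of the limit, while compound 1 and compound 2 remain at it: the limit of > 100000 nM in this assay, at which 2 of the 3 values shown sit.

On these data alone, both steps are open at their upper end, so their full size stays unknown. As far as these compounds go, whether ethyl or a longer chain on the selenium atom would keep the growth inhibition of compound 3, and how benzyl would read on sulfur, also remains open.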